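Chloro to fluoro on the benzyl group: compound 4

The source may report more compounds than this note shows. Statements on the series, on what has been measured and on what is new or still open speak of the compounds shown alone.

Measured so far:
compound 1 `COc1ccc(C2N=C(SCc3ccccc3Cl)NC(C)=C2C(=O)Nc2ccc(F)cc2)cc1OC`: 30.3%
compound 2 `COc1ccc(C2N=C(SCc3cccc(Cl)c3)NC(C)=C2C(=O)Nc2ccc(F)cc2)cc1OC`: 17.4%
compound 3 `COc1ccc(C2N=C(SCc3ccc(Cl)cc3)NC(C)=C2C(=O)Nc2ccc(F)cc2)cc1OC`: 26.7%

In a functional assay on the whole organism (artery, strain albino) with Rattus norvegicus as the target, with a stated time of 600 min, at a dose of 10 mg/kg by the oral route (a lower number here means less inhibition, a higher number more inhibition at the dose given (going by the name of the read-out)), compound 1 gives 30.3%. Compound 2 gives 17.4% and compound 3 gives 26.7%. Compound 3 stands second highest of the three numbers; against compound 1 the step is a number 3.6 percentage points lower from compound 1 to compound 3 (within the scatter), against compound 2 it is a number 9.3 percentage points higher from compound 2 to compound 3 (within the scatter), both within the scatter. Among the measured compounds shown here, the only step beyond the scatter is a number 12.9 percentage points lower from compound 1 to compound 2 (beyond the scatter).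

Compound 4 `COc1ccc(C2N=C(SCc3ccc(F)cc3)NC(C)=C2C(=O)Nc2ccc(F)cc2)cc1OC` differs from compound 3 by fluoro in place of chloro on an aromatic carbon. For the measured compounds named here, no measured step exchanges one halogen for another; the three steps only move the chloro around the ring, and two of them stay within the scatter. No step beyond the scatter is therefore expected in this assay. Compound 4 is expected to give 26%, in the range 12% to 40%. The expected step is a number 0.7 percentage points lower from compound 3 to compound 4 (within the scatter).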

Compound 4, a percentage reported as inhibition, in the whole organism at one dose (the size of the read-out at that dose, not a potency): 21%
The estimate for compound 4 lay 5 percentage points above the measured number; measured number inside the range.
By their numbers in this assay, from the lowest: compounds 2, 4, 3 and 1 (each within the scatter of the next, the first and the last beyond it).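

In this assay the exchange of chloro for fluoro on the aromatic carbon para to a large group gives a number 5.7 percentage points lower from compound 3 to compound 4 (within the scatter) and so stays within the scatter. Compound 4 also lies within the scatter of both other chloro isomers, with a number 3.6 percentage points higher from compound 2 to compound 4 (within the scatter) and a number 9.3 percentage points lower from compound 1 to compound 4 (within the scatter) even though compound 1 and compound 2 lie beyond the scatter of each other. No measurement available here explains these numbers.

Open, going by these compounds, is whether a trifluoromethyl or nitrile group at this position stays in the same range. Also open, on these data alone, is whether an amine or a carboxylic acid there departs from it.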